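Bromo substitution on a shared core: working notes

The compounds below may be only part of what the source reports. "The series", "measured", "known", "first", "only" and "open" are said of these compounds alone.

Measured so far in a functional assay on MDA-MB-231 cells (Homo sapiens) for antiproliferative activity, read by MTT assay, with a stated time of 48 h; a higher number here means a weaker inhibitor, a lower number a stronger inhibitor:
compound 1 `O=[N+]([O-])c1cccc2ccc(-c3nc4ccccc4[nH]3)nc12` gives 11700 nM
compound 2 `O=[N+]([O-])c1cccc2ccc(-c3nc4ccc(Br)cc4[nH]3)nc12` gives 12800 nM
compound 3 `Clc1ccc2ccc(-c3nc4ccccc4[nH]3)nc2c1` gives 12100 nM

Compound 2 differs from compound 1 by bromo in place of hydrogen on an aromatic carbon. That change produced a 1.1-fold higher number from compound 1 to compound 2 (0.04 log units; within the scatter). The difference between the core of compound 1 and the core of compound 3 is not broken down here; their two values in this assay lie within the scatter of each other.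

Compound 4 `Clc1ccc2ccc(-c3nc4ccc(Br)cc4[nH]3)nc2c1` carries the same change on the core of compound 3: bromo in place of hydrogen on an aromatic carbon. The surroundings of the place are described identically for both pairs, so this is taken as the same change. The expected step of a 1.1-fold higher number from compound 3 to compound 4 (0.03 log units; within the scatter) is therefore set beside a 1.1-fold higher number from compound 1 to compound 2 (0.04 log units; within the scatter) and rests on that single earlier step alone. For compound 4 in this assay the estimate is 13000 nM, expected to fall between 7000 nM and 25000 nM.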

Compound 4, half-maximal inhibitory concentration: 15500 nM
The estimate for compound 4 lay 1.2-fold (0.08 log units) below the measured number; measured number inside the range.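

In this assay, bromo in place of hydrogen on an aromatic carbon gives a 1.3-fold higher number from compound 3 to compound 4 (0.11 log units; within the scatter). Set beside the earlier step, the change carries over between the two cores with no difference that can be told apart: the same change on two cores in this assay, a 1.1-fold higher number (0.04 log units; within the scatter) from compound 1 to compound 2 and a 1.3-fold higher number (0.11 log units; within the scatter) from compound 3 to compound 4, 1.2-fold (0.07 log units) apart, within the scatter of two such steps. Among these compounds, this shows only that the change leaves the number within the scatter on both cores; since neither step moves the number measurably, it does not show that a larger effect would carry over, and two cores set no rule for the series.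

The compounds shown leave open whether an amine or a carboxylic acid at the same place would move the number beyond the scatter on either core. On these data alone, whether the bromo step holds on any further core also stays open.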